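Iodo to furan-3-yl on a nucleoside core

The source may hold more compounds than are shown below. What is called first, only, known or untested is meant among the compounds shown, and "the series" means these compounds.

The study measures growth inhibition in a functional assay on CCRF-CEM cells (Homo sapiens), read by MTT assay, with a stated time of 72 h; a higher number here means a weaker inhibitor, a lower number a stronger inhibitor. Within the data shown here, compound 1 `Cc1ncnc2c1c(I)cn2[C@@H]1O[C@H](CO)[C@@H](O)[C@H]1O` gives 5480 nM there, and it is the only compound of the three measured that returns a number at all. Compound 2 `Cc1nc(N)c2c(-c3cccs3)cn([C@@H]3O[C@H](CO)[C@@H](O)[C@H]3O)c2n1` comes back in this assay only as a limit, > 20000 nM. Compound 3 `Cc1nc(N)c2c(-c3ccco3)cn([C@@H]3O[C@H](CO)[C@@H](O)[C@H]3O)c2n1` likewise comes back only as a limit, > 100000 nM. Among the measured compounds shown here, the single computed step, a step that the two limits leave unreadable from compound 2 to compound 3, therefore cannot be read, since both of its ends are limits (the limit of > 20000 nM in this assay, at which 1 of the 3 values shown sits, (the limit of > 100000 nM in this assay, at which 1 of the 3 values shown sits)).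

The step now followed leads from compound 1 to compound 4 `Cc1ncnc2c1c(-c1ccoc1)cn2[C@@H]1O[C@H](CO)[C@@H](O)[C@H]1O`, with the change (furan-3-yl in place of iodo on an aromatic carbon). For the measured compounds named here, no measured step covers this exact change. What the data do show is that the two compounds carrying a five-membered aromatic ring at that position, compound 2 and compound 3, both sit at limits, whereas compound 1 with iodo gives a number. On that basis the account expects a step to weaker inhibition, a 3.6-fold higher number from compound 1 to compound 4 (0.56 log units; beyond the scatter), with a real chance that compound 4 also returns only a limit. Compound 4 is estimated at 20000 nM in this assay, within a range from 5000 nM to 100000 nM.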

Compound 4, half-maximal inhibitory concentration: > 20000 nM
Compound 4 gave a limit, no number; the forecaster's own chance of this, stated with the estimate: 40%; the middle value lies on the limit itself.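

Among these compounds, on the core of compound 1, this is the first readable step at this position, and it is a loss: in this assay, furan-3-yl in place of iodo on the aromatic carbon gives an at least 3.6-fold higher number from compound 1 to compound 4 (0.56 log units; beyond the scatter). The result for compound 4 is a limit and not a number, so the step has a lower bound on its size but no upper one: the limit of > 20000 nM in this assay, at which 2 of the 4 values shown sit. On this core, then, the number seen with iodo does not survive the exchange of that single atom for a five-membered aromatic ring with 1 hetero atom.

On these data alone, whether the loss belongs to the arrival of the furan-3-yl ring or to the departure of iodo stays open, and a small group at the same carbon, such as bromo, methyl or ethynyl, or a ring-bearing group with an amine on it, would begin to separate the two. The step between the thiophen-2-yl and furan-2-yl compounds also still cannot be read, so the data do not say how the choice of ring alters the outcome at this position.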